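Chalcone-linked imidazolones: trimethoxyphenyl swap on the chain

This account rests on a few compounds, and the source may have more. Where it says the series, first, only, none or still open, it means among the compounds named here.

Working notes on a pair of chalcone-bearing imidazolones and one untested variant. Compound 2 `COc1ccc(-c2cn(-c3cccc(C(=O)/C=C/c4ccc(O)c(OC)c4)c3)c(=O)[nH]2)cc1` in a functional assay on SK-MEL-28 cells (Homo sapiens) for inhibition (on this read-out lower numbers stand for stronger inhibition of growth and higher numbers for weaker inhibition of growth), gives 2030 nM. Compound 1 `COc1cc(/C=C/C(=O)c2cccc(-n3cc(-c4ccccc4)[nH]c3=O)c2)cc(OC)c1OC` in this assay gives 1740 nM; these two numbers lie within the scatter of each other, so compound 2 stands level with the only comparator available, and no ordering between them can be read from the data.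

Compound 3 `COc1ccc(-c2cn(-c3cccc(C(=O)/C=C/c4cc(OC)c(OC)c(OC)c4)c3)c(=O)[nH]2)cc1` differs from compound 2 by 3,4,5-trimethoxyphenyl in place of 4-hydroxy-3-methoxyphenyl on a double-bonded chain carbon bound to a double-bonded chain carbon. Going by the values given here, no measured step covers this exchange on this scaffold. Compound 1 also carries a 3,4,5-trimethoxyphenyl on its chain and gives 1740 nM in this assay, a number in the same range as compound 2; on that basis the exchange is expected to produce no step beyond the scatter in this assay, and the estimated step of a 1.2-fold lower number from compound 2 to compound 3 (0.08 log units; within the scatter) is correspondingly small. Compound 3 is therefore estimated at 1700 nM in this assay, with a range from 800 nM to 3600 nM.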

Compound 3, concentration for 50% growth inhibition: 2030 nM
For compound 3 the middle estimate is 1.2-fold (0.08 log units) below the measured one; the range from low to high includes it.
By their numbers in this assay, from the lowest: compounds 1, 2 and 3 (each within the scatter of the next).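

In this assay the exchange of 4-hydroxy-3-methoxyphenyl for 3,4,5-trimethoxyphenyl on a double-bonded chain carbon bound to a double-bonded chain carbon gives no change at the digits printed from compound 2 to compound 3 (within the scatter) on this scaffold, so this position tolerates the loss of the hydrogen-bond donor and the gain of three heavy atoms without a readable shift in this read-out. With the chain group held as 3,4,5-trimethoxyphenyl, methoxy in place of hydrogen on an aromatic carbon gives a 1.2-fold higher number from compound 1 to compound 3 (0.07 log units; within the scatter) and likewise leaves the read-out level. No supporting measurement bears on these two flat steps.

The compounds shown leave open whether a group of a different kind at this chain position, such as an amine or a carboxylic acid, would move the number beyond the scatter. They also leave open whether a step of that kind would carry over to the core of compound 1.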